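A few compounds are considered here, and "the series" means these few. Any claim that something is new, unique, unknown or untested is made for them only; others in the source may bear on it.

Compound 1 `COc1ccccc1CNCc1c(-c2ccccc2)c2cc(C)c(C)cc2c(=O)n1C` gives 13 nM in an assay on IM-9 cells for binding affinity to Substance-P receptor (Homo sapiens); a higher number here means a weaker inhibitor, a lower number a stronger inhibitor.
Compound 2 `Cc1cc2c(-c3ccccc3)c(NC(=O)N(C)Cc3ccccc3)n(C)c(=O)c2cc1C` gives 16 nM in this assay.
Compound 3 `Cc1cc(C)cc(CN(C)C(=O)c2c(-c3ccc(F)cc3)c3cccnc3c(=O)n2C)c1` gives 5.1 nM in this assay.

Among these three, compound 1 stands second highest; its number and that of compound 2 lie within the scatter of each other, while compound 3 sits beyond the scatter below it. Compound 4 `COc1ccccc1CN(C)Cc1c(-c2ccccc2)c2cc(C)c(C)cc2c(=O)n1C` has not yet been measured. It differs from compound 1 in one place: methyl in place of hydrogen on an amine nitrogen. Within the data shown here, no measured pair shows the effect of this change, so the expectation rests on compound 1 alone. The step from compound 1 to compound 4 is expected to be small, a 1.2-fold higher number from compound 1 to compound 4 (0.06 log units; within the scatter), with no direction beyond the scatter. Compound 4 is therefore estimated at 15 nM, within a range from 5 nM to 45 nM.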

Compound 4, half-maximal inhibitory concentration: 800 nM
Compound 4: the middle estimate sits 53-fold (1.73 log units) below what was measured, and the stated range ends below it.
By their numbers in this assay, from the lowest: compound 3; then compounds 1 and 2 (each within the scatter of the next); then compound 4.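

In this assay, one added methyl on the amine nitrogen is enough for a large loss of binding strength, a 62-fold higher number from compound 1 to compound 4 (1.79 log units; beyond the scatter), for a change of a single carbon. The earlier compounds shown here could not show that this nitrogen is so sensitive, since no measured pair had tested it. Nothing shown explains why the loss occurs.

On these data alone, whether an ethyl group, a longer chain or an acetyl group on this nitrogen would be tolerated remains open. This single pair also cannot tell whether methyl would cost as much on another core.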